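The source may report more compounds than this note shows. Statements on the series, on what has been measured and on what is new or still open speak of the compounds shown alone.

Measured compounds:
compound 1, `CCOC(=O)c1sc(-c2cccc(NC(=O)c3ccc(C(F)(F)F)cn3)c2)nc1Nc1ccc(N2CCN(C)CC2)cc1`, 20.8%;
compound 2, `CCOC(=O)c1sc(-c2cccc(NC(=O)c3ccco3)c2)nc1Nc1ccc(N2CCN(C)CC2)cc1`, 87.6%;
compound 3, `CN1CCN(c2ccc(Nc3nc(-c4cccc(NC(=O)c5ccc(C(F)(F)F)cn5)c4)sc3C(N)=O)cc2)CC1`, 84.6%.

All three were tested in a functional assay on Raji cells (Homo sapiens) for antiproliferative activity, read by CCK-8 assay, with a stated time of 72 h, tested at 40 uM; on this read-out higher numbers stand for more inhibition at the one concentration tested (going by the name of the read-out) and lower numbers for less inhibition. Compound 2 differs from compound 1 by furan-2-yl in place of 5-(trifluoromethyl)pyridin-2-yl on a carbonyl carbon, and this change gave a number 66.8 percentage points higher from compound 1 to compound 2 (beyond the scatter). The core of compound 3 differs from the core of compound 1 by amino in place of ethoxy on a carbonyl carbon, with a number 63.8 percentage points higher from compound 1 to compound 3 (beyond the scatter). Compound 3 and compound 2 lie within the scatter of each other. Compound 4, `CN1CCN(c2ccc(Nc3nc(-c4cccc(NC(=O)c5ccco5)c4)sc3C(N)=O)cc2)CC1`, is not yet measured in this assay; it differs from compound 3 by furan-2-yl in place of 5-(trifluoromethyl)pyridin-2-yl on a carbonyl carbon, the same change as between compound 1 and compound 2, at the same place. Because compound 3 already gives 84.6%, the expected step is much smaller than the earlier one, about a number 5.4 percentage points higher from compound 3 to compound 4 (within the scatter); the read-out has little room left to rise. Compound 4 is estimated at 90%, expected to fall between 76% and 98%.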

Compound 4, a percentage reported as inhibition, at one concentration (the size of the read-out at that concentration, not a potency): 84.3%
The estimate for compound 4 lay 5.7 percentage points above the measured number; the measured number falls inside the stated range.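

The change to furan-2-yl did not carry from the core of compound 1 to the core of compound 3 in this assay: the same change on two cores in this assay, a number 66.8 percentage points higher (beyond the scatter) from compound 1 to compound 2 and a number 0.3 percentage points lower (within the scatter) from compound 3 to compound 4, 67.1 percentage points apart, beyond the scatter of two such steps. The change from ethoxy to amino likewise depended on the group at the other end of the molecule: the same change on two cores in this assay, a number 63.8 percentage points higher (beyond the scatter) from compound 1 to compound 3 and a number 3.3 percentage points lower (within the scatter) from compound 2 to compound 4, 67.1 percentage points apart, beyond the scatter of two such steps. Going by these compounds, with a number 0.3 percentage points lower from compound 3 to compound 4 (within the scatter) and a number 3.3 percentage points lower from compound 2 to compound 4 (within the scatter), either change alone matched both changes together in these four compounds, but a single concentration gives no potency, so any difference among compound 2, compound 3 and compound 4 at lower concentrations remains unknown.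

The compounds shown leave open whether the pattern extends to other groups on the amide carbonyl, such as phenyl or thiophen-2-yl. They also leave open how a methylamino or hydroxyl group would behave in place of ethoxy.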